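Swapping Fluoro for Amino Near the Assay Limit

The source may hold more compounds than are shown below. What is called first, only, known or untested is meant among the compounds shown, and "the series" means these compounds.

Measured in a functional assay on P388 cells (Mus musculus) for inhibition; on this read-out lower numbers stand for stronger inhibition and higher numbers for weaker inhibition:
compound 1 `COc1ccc(/C=C/c2ccc3ccccc3c2)cc1` - > 5000 nM (a limit)
compound 2 `COc1ccc(/C=C/c2ccc3ccccc3c2)cc1F` - 4490 nM
compound 3 `Cc1ccc(/C=C/c2ccc3ccccc3c2)cc1` - > 5000 nM (a limit)

Within the data shown here, compound 2, at 4490 nM, is the only compound here with a true number. The other two results are limits, as this summary records: the limit of > 5000 nM in this assay, at which 2 of the 3 values shown sit. No ranking can be drawn from them.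

The unmeasured compound 4 `COc1ccc(/C=C/c2ccc3ccccc3c2)cc1N` has amino in place of fluoro on an aromatic carbon, ortho to a methoxy group (amino in place of fluoro on an aromatic carbon).

The closest evidence is the swap of hydrogen for fluoro (an at least 1.1-fold lower number from compound 1 to compound 2 (0.04 log units; that floor lies within the scatter)), whose floor lies within the scatter. The swap of methoxy for methyl (a step that the two limits leave unreadable from compound 1 to compound 3) cannot be read, and it concerns a different group. Among the measured compounds shown here, no measured step involves an amino group, so no clear shift can be predicted in this assay. The expected change is small, within the scatter (a 1.5-fold lower number from compound 2 to compound 4 (0.18 log units; within the scatter)), though real uncertainty remains. Compound 4 is estimated at 3000 nM, with an expected range from 700 nM to 9000 nM.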

Compound 4, half-maximal inhibitory concentration: > 5000 nM
Compound 4 ended at the assay's limit; the forecaster's own chance of this, stated with the estimate: 35%; at least 1.6-fold (0.22 log units) between middle value and limit.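

In this assay, amino in place of fluoro on an aromatic carbon, ortho to a methoxy group, gives an at least 1.1-fold higher number from compound 2 to compound 4 (0.04 log units; that floor lies within the scatter). From the compounds shown here alone, the result for compound 4 is a limit rather than a true number, so the full size of this step is unknown, but amino, which brings a hydrogen-bond donor that fluoro lacks, shows no sign of stronger inhibition at this position. Steps joining two limits, such as the one from compound 1 to compound 4, cannot be read, and the compounds cannot be ranked because most results sit at the same ceiling: the limit of > 5000 nM in this assay, at which 3 of the 4 values shown sit.

Going by these compounds, whether a hydroxyl, a nitrile or a carboxylic acid at this position would give a number clearly under that ceiling stays open. Also open, on these data alone, is whether chloro would behave as fluoro does in compound 2.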